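This account rests on a few compounds, and the source may have more. Where it says the series, first, only, none or still open, it means among the compounds named here.

Of the compounds shown here, two have numbers so far in an ADME assay on BE(2)-C cells (Homo sapiens) for cytotoxicity, read by MTT assay, with a stated time of 20 h; on this read-out lower numbers stand for higher toxicity in this test and higher numbers for lower toxicity in this test. Compound 1 `C[C@@H](NC(=O)C1CCN(C(=O)c2cc3ccccc3n2Cc2ccc(Cl)cc2)CC1)c1ccncc1` gives 92300 nM, and compound 2 `COc1ccc(Cn2c(C(=O)N3CCC(C(=O)N(C)Cc4ccccc4)CC3)cc3ccccc32)cc1` gives 99200 nM. These two values lie within the scatter of each other, so compound 2 cannot be separated from compound 1 on this read-out. Going by the values given here, no step between measured compounds that differ in one place is available to calibrate a single substitution.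

Compound 3 `CN(Cc1ccccc1)C(=O)C1CCN(C(=O)c2cc3ccccc3n2Cc2ccc(C(F)(F)F)cc2)CC1` departs from compound 2 in one place: trifluoromethyl in place of methoxy on an aromatic carbon. This puts trifluoromethyl in place of methoxy on an aromatic carbon, para to a large group. Among the compounds with values here, the series offers no direct precedent for this exchange. Within the data shown here, the only guide is that compound 1 at 92300 nM and compound 2 at 99200 nM fall within the scatter despite their structural differences, so no shift beyond the scatter is expected here. The expected change is a 1.2-fold lower number from compound 2 to compound 3 (0.07 log units; within the scatter), and its direction remains uncertain. For compound 3 the estimate is 85000 nM, with an expected range from 45000 nM to 160000 nM.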

Compound 3, half-maximal cytotoxic concentration: 90300 nM
Estimate against measurement, compound 3: 1.1-fold (0.03 log units) below; the measured number falls inside the stated range.
By their numbers in this assay, from the lowest: compounds 3, 1 and 2 (each within the scatter of the next).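

Going by these compounds alone, the first one-place step in this assay is a 1.1-fold lower number from compound 2 to compound 3 (0.04 log units; within the scatter), with trifluoromethyl in place of methoxy on an aromatic carbon, para to a large group. This exchange replaces a group of 2 heavy atoms and 1 hydrogen-bond acceptor with one of 4 heavy atoms and 0 hydrogen-bond acceptors, yet the read-out does not separate the two compounds, so this position has now tolerated one direct change without a shift beyond the scatter. No measured property of these compounds bears on this result, so the finding stands as an observation without an explanation.

Within the data shown here, open is whether an amine or a carboxylic acid in place of methoxy on this aromatic carbon would move the number beyond the scatter, since methoxy and trifluoromethyl are the only two groups compared directly here. Also open, from the compounds shown here alone, is whether a longer chain at this position would stay within the scatter, or whether any one-place change elsewhere on the shared core would shift the read-out.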